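Swapping the hydroxylated ring for a pyridine in a hydrazone

The source may report more compounds than this note shows. Statements on the series, on what has been measured and on what is new or still open speak of the compounds shown alone.

Two hydrazone compounds sharing one core have been tested in a functional assay on PC-3 cells (Homo sapiens) for inhibition; a lower number here means a stronger inhibitor, a higher number a weaker inhibitor. Compound 1 `Cc1c(C(=O)N/N=C\c2ccccc2O)oc2cccc(O)c12` gives 8350 nM, and compound 2 `Cc1ccc(O)c(/C=N\NC(=O)c2oc3cccc(O)c3c2C)c1` gives 7350 nM. Going by the values given here, the only step between them, a 1.1-fold lower number from compound 1 to compound 2 (0.06 log units; within the scatter), is too small to count as a real change, so compound 2 has the lowest number of the two without being clearly stronger than compound 1.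

From the compounds shown here alone, compound 3 `Cc1c(C(=O)N/N=C\c2ccncc2)oc2cccc(O)c12` is untested. It differs from compound 2 in one place: pyridin-4-yl in place of 2-hydroxy-5-methylphenyl on a carbon with a double bond to nitrogen. Among the compounds with values here, no measured step touches this part of the molecule; the single step between compounds 1 and 2 only shows that adding a methyl on that ring changes little. With the hydroxyl of that ring gone, a weaker result is expected for compound 3, roughly a 2.0-fold higher number from compound 2 to compound 3 (0.31 log units; beyond the scatter). Compound 3 is therefore estimated at 15000 nM, within a range of 4000 nM to 60000 nM.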

Compound 3, half-maximal inhibitory concentration: >= 40000 nM
Compound 3: only a limit was reported (the forecaster's own chance of this, stated with the estimate: 25%); middle value at least 2.6-fold (0.42 log units) from the limit.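

Replacing the hydroxylated ring with pyridin-4-yl on a carbon with a double bond to nitrogen gives an at least 5.4-fold higher number from compound 2 to compound 3 (0.73 log units; beyond the scatter), and the same replacement of 2-hydroxyphenyl gives an at least 4.7-fold higher number from compound 1 to compound 3 (0.68 log units; beyond the scatter). In this assay, the result for compound 3 is a limit and not an exact number: the limit of >= 40000 nM in this assay, at which 1 of the 3 values shown sits. So this position, where adding a methyl on the ring had made no change beyond the scatter, does respond when the whole ring is exchanged, and the true size of that loss may be larger than these steps can say.

The exchange removes the hydroxyl and brings in a ring nitrogen at once, so the compounds shown cannot tell which of the two matters. A plain phenyl or a 2-methoxyphenyl group at this place would begin to separate them.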